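Removing the amide methyl from a brominated lead

The compounds below may be only part of what the source reports. "The series", "measured", "known", "first", "only" and "open" are said of these compounds alone.

Measured so far:
compound 1 `CNC(=O)/C=C1\CCc2ccc(Br)cc21`: 0%
compound 2 `CNC(=O)/C=C1\CCc2ccc(Cl)cc21`: 16%

In a functional assay on the whole organism with Mus musculus as the target, at a dose of 100 mg/kg by the intraperitoneal route (on this read-out higher numbers stand for more inhibition at the one dose given (going by the name of the read-out) and lower numbers for less inhibition), compound 1 gives 0%, the lowest of the two numbers measured. Its nearest neighbour is compound 2, which gives 16%. Among the compounds with values here, the only step so far, a number 16 percentage points higher from compound 1 to compound 2 (beyond the scatter), swaps one halogen for another on the aromatic ring.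

Compound 3 `NC(=O)/C=C1\CCc2ccc(Br)cc21` has not been measured. It differs from compound 1 by hydrogen in place of methyl on an amide-type nitrogen; cut one bond further out, the change reads methylcarbamoyl to carbamoyl. Within the data shown here, no measured step touches the amide nitrogen, so the halogen step gives no guidance on this change. In the absence of any comparable step, a small or no step beyond the scatter is expected, estimated as a number 5 percentage points higher from compound 1 to compound 3 (within the scatter). Compound 3 is therefore expected to give about 5%, within 0% to 25%.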

Compound 3, a percentage reported as inhibition, in the whole organism at one dose (the size of the read-out at that dose, not a potency): 100%
Estimate against measurement, compound 3: 95 percentage points below, outside the stated range (above it).
By their numbers in this assay, from the lowest: compound 1; then compound 2; then compound 3.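

In this assay, the step of a number 100 percentage points higher from compound 1 to compound 3 (beyond the scatter) shows that an amide-type nitrogen is a highly sensitive place on this core: hydrogen in place of methyl there matters far more than the halogen swap, a number 16 percentage points higher from compound 1 to compound 2 (beyond the scatter). Compound 1 and compound 3 both carry the bromo group, so bromo on its own does not rule out strong inhibition at this single dose. No measurement available here accounts for the change.

The compounds shown leave open whether a larger group on that nitrogen, such as ethyl, would lose the inhibition as methyl does, and whether a carboxylic acid in place of carbamoyl would keep it. They also leave open whether hydrogen in place of methyl would have the same effect on the chloro compound, compound 2.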